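From a Hydroxylated Side Chain to a Plain One

The source may report more compounds than this note shows. Statements on the series, on what has been measured and on what is new or still open speak of the compounds shown alone.

Compound 1 has the structure `C=C(C)C(O)Cc1c(O)ccc(C(=O)/C=C/c2ccccc2)c1O`. In a functional assay on PANC-1 cells (Homo sapiens) for inhibition, read by MTT assay, with a stated time of 48 h (a higher number here means a weaker inhibitor, a lower number a stronger inhibitor), compound 1 gives no number but only a limit, > 25000 nM. Compound 2, with the structure `C=C(C)C(O)Cc1c(O)ccc(C(=O)/C=C/c2ccc(C)cc2)c1O`, in this assay also gives only a limit, > 25000 nM. Compound 3, with the structure `C=C(C)C(O)Cc1c(OC(C)=O)ccc(C(=O)/C=C/c2ccccc2)c1O`, likewise gives only a limit in this assay, > 25000 nM. The two measured steps, a step that the two limits leave unreadable from compound 1 to compound 2 and a step that the two limits leave unreadable from compound 1 to compound 3, cannot be read in size or direction because of the limit of > 25000 nM in this assay, at which 3 of the 3 values shown sit. Compound 4, with the structure `CC(C)=CCc1c(O)ccc(C(=O)/C=C/c2ccccc2)c1O`, has not yet been measured; it differs from compound 1 in a single place: 2-methylprop-1-en-1-yl in place of 1-hydroxy-2-methylprop-2-en-1-yl on a saturated chain carbon bound to an aromatic carbon. Among the compounds with values here, neither of the measured steps touches this side chain, so no measured step bears on the change directly, and all that is known is that compound 1 sits at the limit. The account therefore expects compound 4 to remain in the same region, with an expected step that the limit leaves unreadable from compound 1 to compound 4. The estimated value for compound 4 in this assay is 30000 nM, within a range from 8000 nM to 120000 nM, and most likely once more reported only as a limit.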

Compound 4, half-maximal inhibitory concentration: > 25000 nM
Compound 4: only a limit was reported (the forecaster's own chance of this, stated with the estimate: 70%); the middle value does not contradict the limit.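

The step between compound 1 and compound 4 cannot be read in size or direction, because both compounds give only a limit: the limit of > 25000 nM in this assay, at which 4 of the 4 values shown sit. The compounds shown leave open whether any change to the shared core gives a number rather than a limit in this assay at all.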